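Trimming a long chain again in a cytotoxic polyacetylene

The compounds below may be only part of what the source reports. "The series", "measured", "known", "first", "only" and "open" are said of these compounds alone.

In a functional assay on SK-MEL-2 cells (Homo sapiens) for cytotoxicity (on this read-out lower numbers stand for an effect already at smaller amounts and higher numbers for an effect only at larger amounts of compound), the three measured compounds sit close together. Compound 1, `C#C/C=C\CCCCCCCCCCCCCCC/C=C\CCCC/C=C\CCCCC#C[C@@H](O)C#CCCCCCC/C=C/[C@H](O)C#C`, gives 0.8 ug/mL. Compound 2, `C#C/C=C\CCCCCCCCCCCCCC/C=C\CCCC/C=C\CCCCC#C[C@@H](O)C#CCCCCCC/C=C/[C@H](O)C#C`, gives 1.5 ug/mL, a number that lies within the scatter of compound 1 and below that of compound 3, `C#C/C=C\CCCCCCCCCCCCCC/C=C\CCCC/C=C\CCCC(O)C#CC(O)C#CCCCCCC/C=C/[C@H](O)C#C`, which gives 3.9 ug/mL; only the separation from compound 3 goes beyond the scatter.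

Compound 4, `C#C/C=C\CCCCCCCCCCCCC/C=C\CCCC/C=C\CCCCC#C[C@@H](O)C#CCCCCCC/C=C/[C@H](O)C#C`, has not yet been measured. It differs from compound 2 by a group of 4 heavy atoms (4 carbon; no ring) in place of a group of 5 heavy atoms (5 carbon; no ring), on a saturated chain carbon, ten or more bonds along the chain from a double-bonded chain carbon. This is the same kind of change already seen once: the step from compound 1 to compound 2 removed one carbon from the same saturated stretch and gave a 1.9-fold higher number from compound 1 to compound 2 (0.27 log units; within the scatter), a move that stayed within the scatter. Within the data shown here, no other measured pair isolates this change, so that single step is the only guide.

On that basis a second removal of one chain carbon is expected to move compound 4 little: the estimated step is a 1.3-fold higher number from compound 2 to compound 4 (0.12 log units; within the scatter), lying within the scatter, with a slight lean toward a higher number. Compound 4 is therefore estimated at 2 ug/mL, with a range from 1 ug/mL to 4 ug/mL.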

Compound 4, concentration for half-maximal effect: 3.8 ug/mL
Compound 4: the middle estimate sits 1.9-fold (0.28 log units) below what was measured; low and high end bracket the measured number.
By their numbers in this assay, from the lowest: compounds 1 and 2 (each within the scatter of the next); then compounds 4 and 3 (each within the scatter of the next).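

In this assay, shortening the saturated stretch again no longer stays inside the scatter: the group of 4 heavy atoms (4 carbon; no ring) in place of the group of 5 heavy atoms (5 carbon; no ring) gives a 2.5-fold higher number from compound 2 to compound 4 (0.40 log units; beyond the scatter) and so separates two compounds, whereas the earlier removal, a 1.9-fold higher number from compound 1 to compound 2 (0.27 log units; within the scatter) and no more, did not. Over both removals the series gives a 4.8-fold higher number from compound 1 to compound 4 (0.68 log units; beyond the scatter) in all, so the length of the chain at this saturated chain carbon does register in this read-out, and among compounds 1, 2 and 4 none goes against the direction. Nothing available here explains why the number climbs as the chain shortens.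

The compounds shown leave open whether the rise continues with a still shorter chain or whether a longer chain than that of compound 1 would bring the number lower still. They also do not tell what an amine or an ether oxygen placed within this saturated stretch would do.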